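Compound 1 to compound 3: a bromo step

The source may report more compounds than this note shows. Statements on the series, on what has been measured and on what is new or still open speak of the compounds shown alone.

Compound 1 `N=C(N)N/N=C(/C=C/c1ccccc1)c1ccccc1` gives 17000 nM
Compound 2 `N=C(N)N/N=C(/C=C/c1ccc(-c2ccccc2)cc1)c1ccccc1` gives 800 nM

In a functional assay on MCF7 cells (Homo sapiens) for antiproliferative activity, read by MTT assay, with a stated time of 48 h (on this read-out higher numbers stand for weaker inhibition and lower numbers for stronger inhibition), compound 1 gives 17000 nM and so stands highest of the two numbers measured, with compound 2 as its nearest neighbour. Compound 3 `N=C(N)N/N=C(/C=C/c1ccccc1)c1ccc(Br)cc1` has not yet been measured. It departs from compound 1 by bromo in place of hydrogen on an aromatic carbon, and the same difference, cut one bond further out, reads phenyl to 4-bromophenyl.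

Among the measured compounds shown here, only one measured step bears on this change. It is a 21-fold lower number from compound 1 to compound 2 (1.33 log units; beyond the scatter) and it is large, with phenyl in place of hydrogen on an aromatic carbon. That step also replaces a hydrogen on an aromatic carbon, but the entering group is phenyl, not bromo, and the carbon lies elsewhere in the structure, so it offers only a loose guide. A single step also shows no general pattern. A smaller move in the same direction therefore seems likely, an estimated 2.8-fold lower number from compound 1 to compound 3 (0.45 log units; beyond the scatter) at the middle of the range. Compound 3 is expected at about 6000 nM (estimated range 1800 nM to 18000 nM).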

Compound 3, half-maximal inhibitory concentration: 90 nM
Estimate against measurement, compound 3: 67-fold (1.82 log units) above; the whole stated range lies above it.
By their numbers in this assay, from the lowest: compound 3; then compound 2; then compound 1.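

In this assay, bromo in place of hydrogen on an aromatic carbon, para to a large group, gives a 190-fold lower number from compound 1 to compound 3 (2.28 log units; beyond the scatter) and so marks this place as highly responsive to substitution. Among the compounds shown here, the only earlier step, a 21-fold lower number from compound 1 to compound 2 (1.33 log units; beyond the scatter) with phenyl as the entering group, was made at a different place and left this ring unchanged; the new result shows that a second place on the core of compound 1 also gives a large step, here with an entering group of only 1 heavy atom, with no ring and no net charge. Nothing measured here accounts for the size of this step.

The compounds shown leave open whether another group at this place, such as chloro, fluoro, methoxy, an amine or a carboxylic acid, would give a step of similar size, and whether bromo on another carbon of the same ring would do the same. They also leave open what a single structure carrying both the bromo and the phenyl groups would give in this read-out.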